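The source may hold more compounds than are shown below. What is called first, only, known or untested is meant among the compounds shown, and "the series" means these compounds.

Measured so far:
compound 1, `CCCCNC1CC(C)C(O)C(O)C1O`: 74 nM
compound 2, `CCCCCCCNC1CC(C)C(O)C(O)C1O`: 48 nM

Both numbers come from an assay on kidney for binding affinity to tissue alpha-L-fucosidase (Homo sapiens); a lower number here means a stronger inhibitor, a higher number a weaker inhibitor. Compound 1 has the highest of the two numbers; compound 2 stands nearest to it, and the step reads a 1.5-fold lower number from compound 1 to compound 2 (0.19 log units; within the scatter), a difference that stays within the usual scatter of this assay. Compound 3, `CCCCCCCCCNC1CC(C)C(O)C(O)C1O`, is not yet measured. It differs from compound 1 by pentyl in place of hydrogen on a saturated chain carbon, four bonds along the chain from an amine nitrogen. For the measured compounds named here, the only measured step that bears on this change is the one from compound 1 to compound 2, a shorter lengthening of the same chain at the same place, and it was small. A longer chain may continue in that direction, but nothing measured shows more than a modest shift, so a step of similar or slightly larger size toward a lower number is expected, not clearly beyond the scatter. This amounts to an expected step of a 2.1-fold lower number from compound 1 to compound 3 (0.33 log units; beyond the scatter). Compound 3 is therefore expected to give about 35 nM in this assay, with a range from 12 nM to 100 nM.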

Compound 3, inhibition constant: 110 nM
Beside the measured number, compound 3's estimate is 3.1-fold (0.50 log units) below it; the measured number lies above the stated range.
By their numbers in this assay, from the lowest: compounds 2, 1 and 3 (each within the scatter of the next, the first and the last beyond it).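

In this assay the pentyl in place of hydrogen on a saturated chain carbon, four bonds along the chain from an amine nitrogen, gives a 1.5-fold higher number from compound 1 to compound 3 (0.17 log units; within the scatter) and so leaves the number close to that of the shorter chain. The ethyl further out gives a 2.3-fold higher number from compound 2 to compound 3 (0.36 log units; beyond the scatter) and is the only step among these compounds beyond the scatter, which shows that the small downward step seen earlier does not continue as the chain grows. Nothing available explains this turn in the numbers.

From the compounds shown here alone, whether the number would keep rising with a longer chain remains open, as the three compounds give only this one turn. Going by these compounds, it is also open how a phenyl ring, an amine or a carboxylic acid would read at this position on the shared core.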